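Chain Length and Cytotoxicity in a Cyanoguanidine Series

The source may hold more compounds than are shown below. What is called first, only, known or untested is meant among the compounds shown, and "the series" means these compounds.

Three compounds have been measured in a functional assay on MCF7 cells (Homo sapiens) for cytotoxicity; on this read-out lower numbers stand for stronger inhibition and higher numbers for weaker inhibition:

compound 1, `CC1C(=O)N(CCCCCOc2ccc(Cl)cc2)/C(=N\C#N)N1c1ccncc1`, gives 9260 nM
compound 2, `CC1C(=O)N(CCCCCCOc2ccc(Cl)cc2)/C(=N\C#N)N1c1ccncc1`, gives 270 nM
compound 3, `N#C/N=C1\N(CCCCCCOc2ccc(Cl)cc2)C(=O)C(c2ccccc2)N1c1ccncc1`, gives 1130 nM

Compound 1 and compound 2 share the same core and differ only in the chain that links it to the chlorinated aromatic ring. The change is (4-chlorophenoxy)methyl in place of 4-chlorophenoxy on a saturated chain carbon, five bonds along the chain from an amide-type nitrogen in a ring. That single added chain carbon made a large difference: a 34-fold lower number from compound 1 to compound 2 (1.54 log units; beyond the scatter). Compound 3 keeps the longer chain of compound 2 but carries phenyl in place of methyl on a saturated ring carbon, and this costs some potency: a 4.2-fold higher number from compound 2 to compound 3 (0.62 log units; beyond the scatter). The difference between the core of compound 1 and the core of compound 3 is not broken down here.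

Compound 4, `N#C/N=C1\N(CCCCCCCOc2ccc(Cl)cc2)C(=O)C(c2ccccc2)N1c1ccncc1`, has not yet been measured. It differs from compound 3 by (4-chlorophenoxy)methyl in place of 4-chlorophenoxy on a saturated chain carbon, six bonds along the chain from an amide-type nitrogen in a ring. This is the same kind of change as that from compound 1 to compound 2, but not the same: there the place was on a saturated chain carbon five bonds along the chain from an amide-type nitrogen in a ring, here it is six bonds along. On these data alone, on the phenyl-bearing core the effect of one more chain carbon is untested, so the expectation for compound 4 rests on one earlier step on a different core. The step expected for compound 4 is estimated as a 3.2-fold lower number from compound 3 to compound 4 (0.51 log units; beyond the scatter), an improvement smaller than the earlier one. The estimated value for compound 4 is 350 nM, with a plausible range from 80 nM to 1500 nM.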

Compound 4, half-maximal inhibitory concentration: 1170 nM
The estimate for compound 4 lay 3.3-fold (0.52 log units) below the measured number; the range from low to high includes it.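

On the phenyl-bearing core, one more chain carbon gives a 1.0-fold higher number from compound 3 to compound 4 (0.02 log units; within the scatter) in this assay, so the longer chain of compound 4 brings no gain that can be told apart from the scatter of repeated measurements. Set beside the earlier step on the core of compound 1, the same change clearly does not carry over at the same size: the same change on two cores in this assay, a 34-fold lower number (1.54 log units; beyond the scatter) from compound 1 to compound 2 and a 1.0-fold higher number (0.02 log units; within the scatter) from compound 3 to compound 4, 36-fold (1.55 log units) apart, beyond the scatter of two such steps. This does not show that the core alone decides the outcome, since the two steps also differ in place, one five bonds and the other six bonds along the chain from an amide-type nitrogen in a ring, and two steps cannot separate these influences or explain the gap between them.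

The compounds shown leave open how the chain of compound 4 would behave on the core of compound 1, and how the chain of compound 1 would behave on the core of compound 3, and either pairing would help to tell the effect of the core from the effect of chain length. They also leave open whether a still longer chain, or an ethyl group in place of the methyl or phenyl on the saturated ring carbon, would change the picture.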